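The source may hold more compounds than are shown below. What is called first, only, known or untested is meant among the compounds shown, and "the series" means these compounds.

Compound 1 `NS(=O)(=O)c1ccc2nc(-c3ccc(-c4ccccc4F)cc3)[nH]c2c1` gives 343 nM in an assay on isolated protein for inhibition of acyl-CoA desaturase 1 (Rattus norvegicus); on this read-out higher numbers stand for weaker inhibition and lower numbers for stronger inhibition. Compound 3 `CS(=O)(=O)c1ccc2nc(-c3ccc(-c4ccc(F)cc4)cc3)[nH]c2c1` gives 25 nM in this assay. Compound 2 `CS(=O)(=O)c1ccc2nc(-c3ccc(-c4ccc(Cl)cc4)cc3)[nH]c2c1` gives only a limit in this assay, > 20000 nM, so its place among the measured compounds is known only as the weak end of what has been seen. Within the data shown here, the one single-place step among the measured compounds is an at least 800-fold lower number from compound 2 to compound 3 (2.90 log units; beyond the scatter); since compound 2 sits at the limit of > 20000 nM in this assay, at which 1 of the 3 values shown sits, the true size of that step is open-ended. Compound 4 `CS(=O)(=O)c1ccc2nc(-c3ccc(-c4ccsc4)cc3)[nH]c2c1` is not yet measured. It differs from compound 2 in one place: thiophen-3-yl in place of 4-chlorophenyl on an aromatic carbon. This is not the change that was measured, but both it and the step from compound 2 to compound 3 leave the chloro of compound 2 behind, and that measured step was large and downward. A downward step of comparable kind is therefore expected, with wide uncertainty, and the expected step is an at least 200-fold lower number from compound 2 to compound 4 (2.30 log units; beyond the scatter). The expected value for compound 4 in this assay is 100 nM, within a range from 15 nM to 3000 nM.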

Compound 4, half-maximal inhibitory concentration: 104 nM
Beside the measured number, compound 4's estimate is 1.0-fold (0.02 log units) below it; the measured number falls inside the stated range.
By their numbers in this assay, from the lowest: compound 3; then compound 4; then compound 1. At a limit, above all of these: compound 2.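

At this position, para to a large group, the low numbers are not tied to 4-fluorophenyl: replacing 4-chlorophenyl with thiophen-3-yl gives an at least 190-fold lower number from compound 2 to compound 4 (2.28 log units; beyond the scatter) in this assay, so a five-membered aromatic ring with 1 hetero atom is also accepted here. The two replacements are not equal, since the change from 4-fluorophenyl to thiophen-3-yl gives a 4.2-fold higher number from compound 3 to compound 4 (0.62 log units; beyond the scatter). The size of the step away from 4-chlorophenyl stays open-ended because compound 2 is held at a limit: the limit of > 20000 nM in this assay, at which 1 of the 4 values shown sits.

Whether the chloro alone accounts for the poor result of compound 2 remains open, and an unsubstituted phenyl, or a phenyl carrying methyl or methoxy in place of the halogen, would bear on that. On these data alone, whether thiophen-2-yl or a pyridine ring at this position behaves like thiophen-3-yl also remains open.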